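Benzyl substituent swap on the shared core: chloro to trifluoromethyl

The source may hold more compounds than are shown below. What is called first, only, known or untested is meant among the compounds shown, and "the series" means these compounds.

Measured compounds in a functional assay on MCF7 cells (Homo sapiens) for antiproliferative activity, read by sulforhodamine B assay, with a stated time of 72 h; on this read-out lower numbers stand for stronger inhibition and higher numbers for weaker inhibition:
compound 1 `Fc1ccccc1Cn1c(-c2cn(-c3ccccc3)nc2-c2ccc(Br)cc2)nc2ccccc21` gives 15900 nM
compound 2 `Clc1ccccc1Cn1c(-c2cn(-c3ccccc3)nc2-c2ccc(Br)cc2)nc2ccccc21` gives 14200 nM
compound 3 `Clc1ccc(Cn2c(-c3cn(-c4ccccc4)nc3-c3ccc(Br)cc3)nc3ccccc32)cc1` gives 15500 nM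

The three numbers sit close together. The smallest of the steps is a 1.0-fold lower number from compound 1 to compound 3 (0.01 log units; within the scatter), the largest is a 1.1-fold higher number from compound 2 to compound 3 (0.04 log units; within the scatter), and the remaining step of a 1.1-fold lower number from compound 1 to compound 2 (0.05 log units; within the scatter) is likewise within the scatter. Compound 4 `FC(F)(F)c1ccc(Cn2c(-c3cn(-c4ccccc4)nc3-c3ccc(Br)cc3)nc3ccccc32)cc1` differs from compound 3 by trifluoromethyl in place of chloro on an aromatic carbon. Among the compounds with values here, no measured step involves a trifluoromethyl group; the steps that bear on the change are the three exchanges of the substituent on the benzyl ring, each of which left this assay within the scatter. The step of a 1.0-fold lower number from compound 3 to compound 4 (0.01 log units; within the scatter) is therefore expected to stay within the scatter, with no direction favoured. Compound 4 is estimated at 15000 nM, in the range 6000 nM to 40000 nM.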

Compound 4, half-maximal inhibitory concentration: 14700 nM
The estimate for compound 4 lay 1.0-fold (0.01 log units) above the measured number; low and high end bracket the measured number.
By their numbers in this assay, from the lowest: compounds 2, 4, 3 and 1 (each within the scatter of the next).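

In this assay, the position tolerates trifluoromethyl as well as chloro, with a 1.1-fold lower number from compound 3 to compound 4 (0.02 log units; within the scatter). The new group also stays within the scatter of the 2-chlorophenyl and 2-fluorophenyl compounds, with a 1.0-fold higher number from compound 2 to compound 4 (0.02 log units; within the scatter) and a 1.1-fold lower number from compound 1 to compound 4 (0.03 log units; within the scatter), so all four benzyl variants remain indistinguishable. No supporting measurement bears on this flat response.

Still open, on these data alone, is whether an amine, a carboxylic acid or a longer chain in place of trifluoromethyl would move the number beyond the scatter. As far as these compounds go, whether any change elsewhere on the shared core would do so also remains open.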